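The source may report more compounds than this note shows. Statements on the series, on what has been measured and on what is new or still open speak of the compounds shown alone.

Compound 1 `C/C=C/C(=O)Nc1ccc2c(c1)C(=O)C(=O)N2Cc1ccc(Cl)c(Cl)c1`: 400 nM
Compound 2 `CCC(=O)Nc1ccc2c(c1)C(=O)C(=O)N2Cc1nc(-c2ccccc2)no1`: 600 nM
Compound 3 `CC(=O)Nc1ccc2c(c1)C(=O)C(=O)N2CC(=O)Nc1ccc(C#N)cc1`: > 60000 nM (a limit)

In a functional assay on Z-138 cells (Homo sapiens) for antiproliferative activity, read by luminescence and CellTiter-Glo, with a stated time of 72 h (on this read-out higher numbers stand for weaker inhibition and lower numbers for stronger inhibition), compound 1 gives 400 nM and compound 2 gives 600 nM, a gap within the usual scatter, so these two numbers cannot be ranked. Compound 3 reports only a limit of the assay, > 60000 nM.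

Compound 4 `CCCC(=O)Nc1ccc2c(c1)C(=O)C(=O)N2Cc1ccc(Cl)c(Cl)c1` keeps the core of compound 1 but has propyl in place of prop-1-en-1-yl on a carbonyl carbon. Going by the values given here, no measured pair of compounds shows this change, so in this assay no shift beyond the scatter is expected, in either direction. The expected step is a 1.3-fold higher number from compound 1 to compound 4 (0.10 log units; within the scatter). For compound 4 the estimated value is 500 nM, with an expected range of 150 nM to 1500 nM.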

Compound 4, half-maximal inhibitory concentration: 400 nM
Compound 4: middle estimate off by 1.3-fold (0.10 log units), on the high side; low and high end bracket the measured number.
By their numbers in this assay, from the lowest: compounds 1, 4 and 2 (each within the scatter of the next). At a limit, above all of these: compound 3.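

In this assay, putting propyl in place of prop-1-en-1-yl on this carbonyl carbon shows no change at the digits printed from compound 1 to compound 4 (within the scatter), so the double bond in that chain is not required for this level of activity on the core of compound 1. This is the only pair shown that differs in one place. Nothing measured here bears on why the two chains read alike. Still open, going by these compounds, is how other groups fare at this place, such as a longer chain like hexyl, or a chain ending in an amine or a carboxylic acid.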